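Aryl groups on the aromatic nitrogen of the series

The source may hold more compounds than are shown below. What is called first, only, known or untested is meant among the compounds shown, and "the series" means these compounds.

In a functional assay on HepG2 cells (Homo sapiens) for antiproliferative activity, read by MTT assay (a lower number here means a stronger inhibitor, a higher number a weaker inhibitor), compound 1 `CC1(C)CCc2c(ccc(C(=O)/C=C/c3ccc(OCc4cn(-c5ccc(Cl)cc5)nn4)cc3)c2O)O1` gives 102000 nM, compound 2 `Cc1c(-n2cc(COc3ccc(/C=C/C(=O)c4ccc5c(c4O)CCC(C)(C)O5)cc3)nn2)cccc1[N+](=O)[O-]` gives 115000 nM and compound 3 `CCc1ccccc1-n1cc(COc2ccc(/C=C/C(=O)c3ccc4c(c3O)CCC(C)(C)O4)cc2)nn1` gives 67800 nM. Compound 3 therefore stands level with the other two, as shown by a 1.5-fold lower number from compound 1 to compound 3 (0.18 log units; within the scatter) and a 1.7-fold lower number from compound 2 to compound 3 (0.23 log units; within the scatter).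

Compound 4 `Cc1ccc(-n2cc(COc3ccc(/C=C/C(=O)c4ccc5c(c4O)CCC(C)(C)O5)cc3)nn2)cc1Br` keeps the shared core and differs from compound 3 by 3-bromo-4-methylphenyl in place of 2-ethylphenyl on an aromatic nitrogen. In words, 3-bromo-4-methylphenyl stands in place of 2-ethylphenyl on an aromatic nitrogen. Three measured exchanges at this same place bear on it: the two above and a 1.1-fold higher number from compound 1 to compound 2 (0.05 log units; within the scatter). Among the compounds with values here, none of them leaves the scatter, although the measured set holds no compound with a bromine. No step beyond the scatter is therefore expected in this assay. The estimated step is a 1.3-fold higher number from compound 3 to compound 4 (0.10 log units; within the scatter). For compound 4 the expected value is 85000 nM, with an estimated range of 42000 nM to 170000 nM.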

Compound 4, half-maximal inhibitory concentration: 110000 nM
The estimate for compound 4 lay 1.3-fold (0.11 log units) below the measured number; the range from low to high includes it.
By their numbers in this assay, from the lowest: compounds 3, 1, 4 and 2 (each within the scatter of the next).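

Bromine now appears at this position for the first time, and 3-bromo-4-methylphenyl stays within the scatter of all three other aryl groups in this assay (a 1.6-fold higher number from compound 3 to compound 4 (0.21 log units; within the scatter); a 1.0-fold lower number from compound 2 to compound 4 (0.02 log units; within the scatter); a 1.1-fold higher number from compound 1 to compound 4 (0.03 log units; within the scatter)). The exchange with 2-ethylphenyl keeps the count of 8 heavy atoms and replaces a carbon with bromine, and the step still stays within the scatter, so all six pairs among compounds 1 to 4 now read as level, with no exception among them. No supporting measurement is available to explain this flat reading.

Going by these compounds, it remains open whether any group on this aromatic nitrogen can produce a step beyond the scatter. A phenyl ring bearing an amine or a carboxylic acid, or a longer alkyl chain in place of the aryl ring, would test this.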